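The source may hold more compounds than are shown below. What is called first, only, known or untested is meant among the compounds shown, and "the series" means these compounds.

Compound 1, `Cc1c(C(=O)Nc2ccc(Oc3ccnc4[nH]ccc34)c(F)c2)nnn1-c1ccccc1F`: 180 nM
Compound 2, `Cc1c(C(=O)Nc2ccc(Oc3ccnc4[nH]ccc34)c(F)c2)nnn1-c1ccc(F)cc1`: 120 nM

In a functional assay on HT-29 cells (Homo sapiens) for cytotoxicity, read by MTT assay, with a stated time of 72 h (on this read-out higher numbers stand for weaker inhibition and lower numbers for stronger inhibition), compound 2 gives 120 nM, and compound 1 gives 180 nM. The single measured step, a 1.5-fold lower number from compound 1 to compound 2 (0.18 log units; within the scatter), lies within the scatter, so the two compounds cannot be told apart on the numbers shown; compound 2 simply carries the lower of two numbers that are, for practical purposes, the same.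

Compound 3, `COc1ccc(-n2nnc(C(=O)Nc3ccc(Oc4ccnc5[nH]ccc45)c(F)c3)c2C)cc1`, is the next compound, and it differs from compound 2 by methoxy in place of fluoro on an aromatic carbon. Within the data shown here, no measured step bears directly on this exchange: the only step available moves a fluoro group around the phenyl ring rather than replacing it, and its size, a 1.5-fold lower number from compound 1 to compound 2 (0.18 log units; within the scatter), was small. With nothing in the data pointing to a large move in either direction, the expected step for compound 3 is a 1.3-fold higher number from compound 2 to compound 3 (0.10 log units; within the scatter), within the scatter. Compound 3 is therefore estimated at 150 nM in this assay, with a range from 50 nM to 450 nM.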

Compound 3, half-maximal inhibitory concentration: 590 nM
The estimate for compound 3 lay 3.9-fold (0.59 log units) below the measured number; the whole stated range lies below it.
By their numbers in this assay, from the lowest: compounds 2 and 1 (each within the scatter of the next); then compound 3.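

In this assay, among these compounds, replacing fluoro with methoxy on this aromatic carbon, para to a large group, gives a 4.9-fold higher number from compound 2 to compound 3 (0.69 log units; beyond the scatter), the first step to lie beyond the scatter. Moving the fluoro group around the phenyl ring had given only a 1.5-fold lower number from compound 1 to compound 2 (0.18 log units; within the scatter), so the identity of the group at this place shows an effect on the number that the fluoro pair could not reveal. The result also separates compound 3 from the 2-fluorophenyl analogue, with a 3.3-fold higher number from compound 1 to compound 3 (0.52 log units; beyond the scatter), and nothing available accounts for the loss.

As far as these compounds go, it remains open whether the higher number is specific to methoxy or extends to other groups here. A hydroxyl, an amine or a chlorine at this carbon could fall nearer either compound 2 or compound 3.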